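The source may report more compounds than this note shows. Statements on the series, on what has been measured and on what is new or still open speak of the compounds shown alone.

Among the measured compounds shown here, in a functional assay on PC-9 cells (Homo sapiens) for inhibition, read by MTT assay, with a stated time of 72 h (on this read-out higher numbers stand for weaker inhibition and lower numbers for stronger inhibition), compound 1 `Cc1cc(Nc2cc(-c3ccccc3)[nH]n2)n2nc(SCc3ccc([N+](=O)[O-])cc3)nc2n1` gives 7980 nM and compound 2 `Cc1cc(Nc2cc(-c3ccccc3)[nH]n2)n2nc(SCc3ccc(Cl)cc3)nc2n1` gives 6710 nM as the only two numbers so far. These lie within the usual scatter of each other, so compound 2 stands level with compound 1 and not apart from it. Compound 3 `C=CCSc1nc2nc(C)cc(Nc3cc(-c4ccccc4)[nH]n3)n2n1` keeps the shared core and differs from compound 2 in the chain on the sulfur, where vinyl in place of 4-chlorophenyl on a saturated chain carbon bound to a sulfur is the counted change: vinyl in place of 4-chlorophenyl on a saturated chain carbon bound to a sulfur, which also reads as 4-chlorobenzyl to allyl. For the measured compounds named here, the one measured step, a 1.2-fold lower number from compound 1 to compound 2 (0.08 log units; within the scatter) as chloro replaces nitro, stays within the scatter, but it only swaps a group on the aromatic ring, and compound 3 loses that ring altogether. Going by the values given here, no measured step covers such a loss, so the data offer no size to carry over, and in this assay the expectation is no step beyond the scatter, with real uncertainty in both directions. The expected step is a 1.2-fold higher number from compound 2 to compound 3 (0.08 log units; within the scatter) on this estimate. For compound 3 the estimated value is 8000 nM with an expected range from 3000 nM to 22000 nM around it.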

Compound 3, half-maximal inhibitory concentration: > 50000 nM
Compound 3 was reported as a limit; the forecaster's own chance of this, stated with the estimate: 10%; middle value at least 6.2-fold (0.79 log units) away from the limit.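

In this assay the entry for compound 3 is a limit of the assay and not a number: the limit of > 50000 nM in this assay, at which 1 of the 3 values shown sits. At this place on the sulfur chain, the change from 4-chlorobenzyl to allyl gives an at least 7.4-fold higher number from compound 2 to compound 3 (0.87 log units; beyond the scatter), and the same exchange, made with the ring that carries nitro, gives an at least 6.2-fold higher number from compound 1 to compound 3 (0.79 log units; beyond the scatter). Among the compounds shown here, the earlier swap of a group on the aromatic ring, a 1.2-fold lower number from compound 1 to compound 2 (0.08 log units; within the scatter), stayed within the scatter, whereas these two steps, in which the whole aromatic ring leaves, are the first to go beyond it, so this position can respond strongly even though the ring swap showed no such response.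

Compound 3 removes the aromatic ring and leaves a group with fewer heavy atoms in one change, and the compounds shown do not tell these two differences apart. Going by these compounds, whether a plain benzyl group with nothing on its ring, or a longer chain such as hexyl on the sulfur, would keep the number close to those of compound 1 and compound 2 stays open.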